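From 3,4-dichlorophenyl to 2-chlorophenyl in compound 3

The source may hold more compounds than are shown below. What is called first, only, known or untested is meant among the compounds shown, and "the series" means these compounds.

Going by the values given here, in a functional assay on HT-29 cells (Homo sapiens) for antiproliferative activity, read by MTT assay, with a stated time of 24 h (a lower number here means a stronger inhibitor, a higher number a weaker inhibitor), compound 2 `COc1ccc(C(=O)/C=C/c2ccc(Cl)c(Cl)c2)c2c1C=CC(C)(C)O2` gives 7580 nM, the only actual number so far. Compound 1 `COc1ccc(C(=O)/C=C/c2ccc(Cl)cc2)c2c1C=CC(C)(C)O2` gives > 10000 nM, which is a limit of the assay and not a number. Compound 3 `COc1ccc(C(=O)/C=C/c2ccccc2Cl)c2c1C=CC(C)(C)O2` has not yet been measured and differs from compound 2 in one place: 2-chlorophenyl in place of 3,4-dichlorophenyl on a double-bonded chain carbon bound to a double-bonded chain carbon. Among the compounds with values here, only one measured step bears on this change, chloro in place of hydrogen on an aromatic carbon, which gives an at least 1.3-fold lower number from compound 1 to compound 2 (0.12 log units; that floor lies within the scatter). Neither measured compound carries the 2-chlorophenyl group, so this step offers only weak guidance. On the strength of that small step, the expected change is a 1.2-fold higher number from compound 2 to compound 3 (0.07 log units; within the scatter), with no shift beyond the scatter anticipated. Compound 3 is estimated at 9000 nM, with an expected range of 4000 nM to 20000 nM. A reading that reports only a limit would be no surprise.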

Compound 3, half-maximal inhibitory concentration: > 10000 nM
Compound 3: no number, only a limit (the forecaster's own chance of this, stated with the estimate: 50%); at least 1.1-fold (0.04 log units) between middle value and limit.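

In this assay, moving from 3,4-dichlorophenyl to 2-chlorophenyl on the double-bonded chain carbon gives an at least 1.3-fold higher number from compound 2 to compound 3 (0.12 log units; that floor lies within the scatter). Compound 3 reads only as a limit of the assay, so the true step could be larger, but what can be read does not go beyond the scatter. Among these three compounds only compound 2, with 3,4-dichlorophenyl, gives an actual number, yet that alone does not set it clearly apart, and the step from compound 1 to compound 3 cannot be read because both rest at the same limit: the limit of > 10000 nM in this assay, at which 2 of the 3 values shown sit.

As far as these compounds go, how the 2-chlorophenyl and 4-chlorophenyl groups compare therefore stays open. Also open, from the compounds shown here alone, is whether a different group at this place, such as 4-methoxyphenyl or 4-aminophenyl, would give a number clearly lower than that of compound 2.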